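One ring swap, two cores, and metabolic half-life

A few compounds are considered here, and "the series" means these few. Any claim that something is new, unique, unknown or untested is made for them only; others in the source may bear on it.

Compound 1 `CCn1c(-c2cnc(C)nc2)nc2c(N[C@H]3CCN(C(=O)[C@H]4C[C@@H](OC)C4)C3)ncnc21` and compound 2 `CCn1c(-c2cnc(C)nc2)nc2c(N[C@H]3CCN(C(=O)C4CC(F)(F)C4)C3)ncnc21` share one core and differ in a single spot. In an ADME assay (Rattus norvegicus, strain Wistar Han) for metabolic stability (on this read-out higher numbers stand for a longer-lived compound and lower numbers for a shorter-lived compound), compound 1 gives 2.3 h, while compound 2 gives 0.4 h. The change between them is 3,3-difluorocyclobutyl in place of 3-methoxycyclobutyl on a carbonyl carbon and it brought a 5.8-fold lower number from compound 1 to compound 2 (0.76 log units; beyond the scatter). Compound 3 `CCn1c(-c2cnc(C)nc2)nc2c(O[C@H]3CCN(C(=O)[C@H]4C[C@@H](OC)C4)C3)ncnc21` carries the same 3-methoxycyclobutyl group on a second core; how the two cores differ is not broken down here. In this assay compound 3 gives 1.8 h, a number that sits within the usual scatter of compound 1. Compound 4 `CCn1c(-c2cnc(C)nc2)nc2c(O[C@H]3CCN(C(=O)C4CC(F)(F)C4)C3)ncnc21` has not yet been measured. It is related to compound 3 by 3,3-difluorocyclobutyl in place of 3-methoxycyclobutyl on a carbonyl carbon, the same change that separates compound 1 from compound 2, at a place described in the same words. Compound 4 is therefore expected to show a step of a 5.1-fold lower number from compound 3 to compound 4 (0.71 log units; beyond the scatter). That expectation rests on a 5.8-fold lower number from compound 1 to compound 2 (0.76 log units; beyond the scatter), applied to compound 3 and its value of 1.8 h. The estimate for compound 4 in this assay is 0.35 h, most likely between 0.15 h and 0.8 h.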

Compound 4, half-life: 1.4 h
The estimate for compound 4 lay 4.0-fold (0.60 log units) below the measured number; the measured number lies above the stated range.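

On the second core, putting 3,3-difluorocyclobutyl in place of 3-methoxycyclobutyl gave a 1.3-fold lower number from compound 3 to compound 4 (0.11 log units; within the scatter) in this assay, so the clear drop seen on the core of compound 1 did not reappear. Set side by side, the two steps do not match: the same change on two cores in this assay, a 5.8-fold lower number (0.76 log units; beyond the scatter) from compound 1 to compound 2 and a 1.3-fold lower number (0.11 log units; within the scatter) from compound 3 to compound 4, 4.5-fold (0.65 log units) apart, beyond the scatter of two such steps. For the compounds shown here, in this series, then, the size of this change on one core cannot simply be carried over to the other, but with only one pair on each core, the data do not show why the steps differ, which part of the cores matters, or how any other change would carry over.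

The compounds shown leave open whether a plain cyclobutyl or a trifluoromethyl group on the same carbonyl carbon would also give a large step on the core of compound 1 and a small one on the core of compound 3. They also leave open whether the two cores would diverge in the same way in another species.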